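A hydroxymethyl swap on a triple-bonded carbon

The source may hold more compounds than are shown below. What is called first, only, known or untested is meant among the compounds shown, and "the series" means these compounds.

Compound 1 `Nc1ccc(S(=O)(=O)N2CCN(c3ncc(C(O)(C(F)(F)F)C(F)(F)F)cc3C3CC3)CC2)cn1`: 27 mL.min-1.g-1
Compound 2 `Nc1ccc(S(=O)(=O)N2CCN(c3ncc(C(O)(C(F)(F)F)C(F)(F)F)cc3C#CC3CC3)CC2)cn1`: 67 mL.min-1.g-1

In an ADME assay (liver) for metabolic stability, with Liver microsome (Rattus norvegicus) as the target, using microsomes and NADPH, with a stated time of 30 min, tested at 1 uM (a lower number here means slower removal, a higher number faster removal of the compound), compound 2 stands highest of the two measured compounds at 67 mL.min-1.g-1, while compound 1 gives 27 mL.min-1.g-1. The next compound, compound 3 `Nc1ccc(S(=O)(=O)N2CCN(c3ncc(C(O)(C(F)(F)F)C(F)(F)F)cc3C#CCO)CC2)cn1`, has not yet been measured. It differs from compound 2 as follows: hydroxymethyl in place of cyclopropyl on a triple-bonded carbon. In words, hydroxymethyl takes the place of cyclopropyl on a triple-bonded carbon, so 2-cyclopropylethynyl becomes 3-hydroxyprop-1-yn-1-yl.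

Among the compounds with values here, only one measured step bears on this change, and only indirectly: a 2.5-fold higher number from compound 1 to compound 2 (0.39 log units; beyond the scatter). It is a modest step, in which 2-cyclopropylethynyl replaced cyclopropyl on an aromatic carbon. Within the data shown here, no measured compound carries hydroxymethyl, so the size of the new step cannot be read directly from the data. The triple-bonded carbon stays in compound 3 while the cyclopropyl leaves, and the expectation is therefore a downward move in this assay, of about the size of that one measured step and beyond the scatter. The expected step is a 2.7-fold lower number from compound 2 to compound 3 (0.43 log units; beyond the scatter). For compound 3 the estimated value is 25 mL.min-1.g-1, with an expected range from 10 mL.min-1.g-1 to 55 mL.min-1.g-1.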

Compound 3, intrinsic clearance in microsomes: 65 mL.min-1.g-1
For compound 3 the middle estimate is 2.6-fold (0.41 log units) below the measured one; the whole stated range lies below it.
By their numbers in this assay, from the lowest: compound 1; then compounds 3 and 2 (each within the scatter of the next).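

In this assay, hydroxymethyl in place of cyclopropyl on a triple-bonded carbon gives a 1.0-fold lower number from compound 2 to compound 3 (0.01 log units; within the scatter), so for this pair, exchanging a three-membered carbon ring for a group with a hydrogen-bond donor and acceptor shows no difference beyond the scatter. Set against the cyclopropyl of compound 1 on an aromatic carbon, 3-hydroxyprop-1-yn-1-yl gives a 2.4-fold higher number from compound 1 to compound 3 (0.38 log units; beyond the scatter), and with a 2.5-fold higher number from compound 1 to compound 2 (0.39 log units; beyond the scatter) this means that in the compounds shown the higher number goes with both groups that carry the triple-bonded carbons, not only with the one ending in cyclopropyl. Nothing measured here explains why these two end groups give results within the scatter of each other.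

The compounds shown leave open whether other groups on the triple-bonded carbon, such as an amine, a carboxylic acid or a longer chain, would also stay within the scatter of compound 2 and compound 3. They also leave open whether hydroxymethyl placed directly on the aromatic carbon, with no triple-bonded carbons, would give a number nearer that of compound 1.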